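From 4-methylphenyl to 4-chlorophenyl

This account rests on a few compounds, and the source may have more. Where it says the series, first, only, none or still open, it means among the compounds named here.

Going by the values given here, in a physicochemical assay for lipophilicity, read by HPLC (a higher number here means a more lipophilic compound, a lower number a more polar compound), compound 1 `O=C1/C(=C\c2ccccc2)C(c2ccccc2)Oc2ccccc21` gives 3.9 and compound 2 `Cc1ccc(/C=C2\C(=O)c3ccccc3OC2c2ccccc2)cc1` gives 4.39, the higher of the two numbers so far. Compound 3 `O=C1/C(=C\c2ccc(Cl)cc2)C(c2ccccc2)Oc2ccccc21` is not yet measured. The change is chloro in place of methyl on an aromatic carbon, para to a large group, or 4-methylphenyl to 4-chlorophenyl.

Among the compounds with values here, one measured step bears on this: a number 0.49 log units higher from compound 1 to compound 2 (beyond the scatter), modest and beyond the scatter, for methyl in place of hydrogen on an aromatic carbon. Within the data shown here, no measured compound carries chloro, so this single step is weak guidance. The swap exchanges one heavy atom for one heavy atom, and no change beyond the scatter is expected in this assay. The expected step is a number 0.06 log units higher from compound 2 to compound 3 (within the scatter), with no firm direction. In this assay, compound 3 is estimated at 4.45, with an expected range of 4.1 to 4.8.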

Compound 3, partition coefficient: 4.53
For compound 3 the middle estimate is 0.08 log units below the measured one; measured number inside the range.
By their numbers in this assay, from the lowest: compound 1; then compounds 2 and 3 (each within the scatter of the next).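

In this assay, chloro in place of methyl on an aromatic carbon, para to a large group, leaves the two compounds unseparated (a number 0.14 log units higher from compound 2 to compound 3 (within the scatter)). Chloro in place of hydrogen at the same position gives a step beyond the scatter (a number 0.63 log units higher from compound 1 to compound 3 (beyond the scatter)), so a second group, not only methyl, now stands apart from hydrogen here. Nothing measured on hand gives a reason for these numbers.

The compounds shown leave open whether a group of another kind at this position, such as an amine or a carboxylic acid, would stay close to methyl and chloro or fall nearer compound 1. They also leave open whether chloro or methyl elsewhere on the shared core would give similar steps.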